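Working notes: from compound 3 to compound 4

A few compounds are considered here, and "the series" means these few. Any claim that something is new, unique, unknown or untested is made for them only; others in the source may bear on it.

Measured in a functional assay on KB cells (Homo sapiens) for cytotoxicity; on this read-out lower numbers stand for an effect already at smaller amounts and higher numbers for an effect only at larger amounts of compound:
- compound 1 `COC1=C(C)C(=O)/C(=C(O)/C=C/c2ccc(Br)cc2)C(=O)C1(C)C`: 1.7 ug/mL
- compound 2 `COC1=C(C)C(=O)/C(=C(O)/C=C/c2ccc(C)cc2)C(=O)C1(C)C`: 3.9 ug/mL
- compound 3 `CCc1ccc(/C=C/C(O)=C2/C(=O)C(C)=C(OC)C(C)(C)C2=O)cc1`: 6.9 ug/mL

In this assay compound 3 stands at 6.9 ug/mL, level with compound 2 within the scatter and above compound 1 beyond it. Compound 4 `COC1=C(C)C(=O)/C(=C(O)/C=C/c2ccco2)C(=O)C1(C)C` carries furan-2-yl in place of 4-ethylphenyl on a double-bonded chain carbon bound to a double-bonded chain carbon. Within the data shown here, three measured steps bear on this only loosely, since each changes one substituent and none replaces the whole aromatic group. These are a 2.3-fold higher number from compound 1 to compound 2 (0.36 log units; beyond the scatter), a 4.1-fold higher number from compound 1 to compound 3 (0.61 log units; beyond the scatter) and a 1.8-fold higher number from compound 2 to compound 3 (0.25 log units; within the scatter). Among the measured compounds shown here, the steps so far stay modest, so no change beyond the scatter is expected in this assay. The expected step is a 1.7-fold lower number from compound 3 to compound 4 (0.24 log units; within the scatter). For compound 4 the estimated value is 4 ug/mL, with an expected range of 1.3 ug/mL to 13 ug/mL.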

Compound 4, concentration for half-maximal effect: 9.9 ug/mL
Estimate against measurement, compound 4: 2.5-fold (0.39 log units) below; the range from low to high includes it.
By their numbers in this assay, from the lowest: compound 1; then compounds 2, 3 and 4 (each within the scatter of the next, the first and the last beyond it).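

In this assay the aromatic group as a whole can be exchanged at this position: furan-2-yl in place of 4-ethylphenyl gives a 1.4-fold higher number from compound 3 to compound 4 (0.16 log units; within the scatter) and so stays level, while the same exchange against the other two aromatic groups gives a 2.5-fold higher number from compound 2 to compound 4 (0.40 log units; beyond the scatter) and a 5.8-fold higher number from compound 1 to compound 4 (0.77 log units; beyond the scatter) as well. The five-membered ring thus joins the upper end of the series, and compound 1 remains the lowest. No evidence is available to explain these steps.

As far as these compounds go, whether thiophen-2-yl or pyridin-3-yl at this position would stay level with furan-2-yl remains open. So does whether a bromo group on the furan ring would bring the lower number of compound 1.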